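The compounds below may be only part of what the source reports. "The series", "measured", "known", "first", "only" and "open" are said of these compounds alone.

In a functional assay on MCF7 cells (Homo sapiens) for antiproliferative activity, read by MTT assay, with a stated time of 72 h (on this read-out higher numbers stand for weaker inhibition and lower numbers for stronger inhibition), three compounds have been measured so far, and each result is a limit of the assay:

Compound 1 `COc1cc(-c2ncnn2-c2ccc([N+](=O)[O-])cc2)cc(OC)c1OC` gives > 10000 nM as a limit
Compound 2 `COc1cc(-c2ncnn2-c2ccc(N)cc2)cc(OC)c1OC` gives > 10000 nM as a limit
Compound 3 `COc1cc(-c2ncnn2-c2ccc(Cl)cc2)cc(OC)c1OC` gives > 10000 nM as a limit

Compound 3 therefore has no number of its own, and the two other results beside it are limits too (the limit of > 10000 nM in this assay, at which 3 of the 3 values shown sit). The next compound, compound 4 `COc1cc(-c2ncnn2-c2ccccc2)cc(OC)c1OC`, loses the chloro group: hydrogen in place of chloro on an aromatic carbon, para to a large group, or 4-chlorophenyl to phenyl.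

For the measured compounds named here, the steps that bear on this change are a step that the two limits leave unreadable from compound 1 to compound 2, a step that the two limits leave unreadable from compound 1 to compound 3 and a step that the two limits leave unreadable from compound 2 to compound 3, each an exchange of one group on an aromatic carbon. None of them has a readable size, but nitro, amino and chloro all leave the compound at the same limit. On that footing, no step beyond the scatter is expected in this assay, and no direction can be given. The estimated change is a step that the limit leaves unreadable from compound 3 to compound 4 and should be read with that caution. Compound 4 is expected at 15000 nM, with an estimated range from 8000 nM to 40000 nM, and it will most likely be reported only as a limit.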

Compound 4, half-maximal inhibitory concentration: > 10000 nM
Compound 4 was reported as a limit (the forecaster's own chance of this, stated with the estimate: 85%); the middle value is on the limit's open side.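

In this assay compound 4 gives > 10000 nM, which is a limit of the assay. For the compounds shown here, no step between compound 4 and compound 1, compound 2 or compound 3 can be read, since all four results are limits: the limit of > 10000 nM in this assay, at which 4 of the 4 values shown sit. The compounds shown leave open whether hydrogen, chloro, amino and nitro on this aromatic carbon differ at all in antiproliferative activity.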